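Moving from an aromatic amide to a diol chain

A few compounds are considered here, and "the series" means these few. Any claim that something is new, unique, unknown or untested is made for them only; others in the source may bear on it.

Four compounds share one core and differ only in the group carried on an amide-type nitrogen. Compound 1 `CCn1c(C(=O)NCCCN(C)C)ccc1C(CC)(CC)c1ccc(OCCC(O)(CC)CC)c(C)c1` gives 2420 nM in an ADME assay on L02 cells (Homo sapiens) for antiproliferative activity, read by MTT assay, with a stated time of 48 h; a higher number here means a weaker inhibitor, a lower number a stronger inhibitor. Compound 2 `CCn1c(C(=O)Nc2ccc(OC(F)(F)F)cc2)ccc1C(CC)(CC)c1ccc(OCCC(O)(CC)CC)c(C)c1` is known in this assay only as a limit, namely > 50000 nM. Compound 3 `CCC(C)C(CO)NC(=O)c1ccc(C(CC)(CC)c2ccc(OCCC(O)(CC)CC)c(C)c2)n1CC` likewise returns only a limit, > 50000 nM. Compound 2 therefore stands at the upper edge of what the assay reports, and the same is true of the limit of > 50000 nM in this assay, at which 2 of the 3 values shown sit.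

The unmeasured compound 4 `CCn1c(C(=O)NC(CO)CCO)ccc1C(CC)(CC)c1ccc(OCCC(O)(CC)CC)c(C)c1` arises from compound 2 by one change: 3-hydroxy-1-(hydroxymethyl)propyl in place of 4-(trifluoromethoxy)phenyl on an amide-type nitrogen. The measured steps that touch compound 2 are an at least 20-fold higher number from compound 1 to compound 2 (1.31 log units; beyond the scatter) and a step that the two limits leave unreadable from compound 2 to compound 3. The first shows that exchanging the basic chain of compound 1 for the aromatic group pushed the number past the limit; the second, between two limits, cannot be sized. Also relevant is an at least 20-fold higher number from compound 1 to compound 3 (1.31 log units; beyond the scatter), where a hydroxyl-bearing chain gave a limit just as the aromatic group did. Compound 4 carries a hydroxyl-bearing chain without a basic amine, so it is expected to resemble compound 3 and to stay at the limit, with a step that the limit leaves unreadable from compound 2 to compound 4 expected to be no step beyond the scatter. The expected value for compound 4 is 60000 nM, within 15000 nM to 200000 nM.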

Compound 4, half-maximal inhibitory concentration: 3040 nM
Beside the measured number, compound 4's estimate is 20-fold (1.30 log units) above it; measured number below the stated range.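

Among these compounds, compounds 1 to 3 left the 3-(dimethylamino)propyl chain of compound 1 as the only group on this amide-type nitrogen with a value below the limit, but compound 4 shows that a chain without an amine can also do this: 3-hydroxy-1-(hydroxymethyl)propyl gives a 1.3-fold higher number from compound 1 to compound 4 (0.10 log units; within the scatter) in this assay. The same chain in place of 4-(trifluoromethoxy)phenyl gives an at least 16-fold lower number from compound 2 to compound 4 (1.21 log units; beyond the scatter), while 2-hydroxyethyl in place of sec-butyl on a saturated chain carbon gives an at least 16-fold lower number from compound 3 to compound 4 (1.21 log units; beyond the scatter), showing that hydroxyl-bearing chains on this nitrogen do not all behave alike, with compound 3 standing against compound 4. Both of these steps start from a limit rather than a number, which leaves their full size unknown, and the step between the two limits cannot be read at all: the limit of > 50000 nM in this assay, at which 2 of the 4 values shown sit.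

On these data alone, it remains open which feature of the compound 4 chain matters, and a simple 3-hydroxypropyl chain or a chain ending in a carboxylic acid would help to separate the effect of the branch from that of the hydroxyl groups. As far as these compounds go, how compound 1 and compound 4 compare in any cell line other than those of this assay also stays open.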